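Swapping pyridin-3-yl for cyclopentyl on the shared core

The source may hold more compounds than are shown below. What is called first, only, known or untested is meant among the compounds shown, and "the series" means these compounds.

Measured so far in a functional assay on MCF7 cells (Homo sapiens) for cytotoxicity, read by WST assay, with a stated time of 72 h (on this read-out lower numbers stand for stronger inhibition and higher numbers for weaker inhibition), are three compounds:
- Compound 1 `Cc1ccc(C2(c3ccc(O)cc3)C(=O)Nc3c2ccc(F)c3F)cc1` gives 1.7 nM as a single entry
- Compound 2 `COc1ccc(C2(c3ccc(O)cc3)C(=O)Nc3c2ccc(F)c3F)cc1` gives 2.1 nM; 6.3 nM; > 1000 nM (3 entries) as several entries and no single number
- Compound 3 `O=C1Nc2c(ccc(F)c2F)C1(c1ccc(O)cc1)c1cccnc1` gives 63 nM as a single entry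

Among the single numbers, compound 3 stands highest. Compound 4 `O=C1Nc2c(ccc(F)c2F)C1(c1ccc(O)cc1)C1CCCC1` carries cyclopentyl in place of pyridin-3-yl on a saturated ring carbon, and cyclopentyl in place of pyridin-3-yl on a saturated ring carbon gives the count of that change. Within the data shown here, only one measured step bears on this place, a 37-fold higher number from compound 1 to compound 3 (1.57 log units; beyond the scatter) and it is large. Among the measured compounds shown here, with pyridin-3-yl leaving, part of that step is expected to return, though cyclopentyl is not aromatic and no measured compound tests it. The step expected in this assay is a 3.2-fold lower number from compound 3 to compound 4 (0.50 log units; beyond the scatter) and it remains an estimate. The estimate for compound 4 is 20 nM with an expected range of 3 nM to 150 nM for its measurement.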

Compound 4, half-maximal inhibitory concentration: 12 nM
Beside the measured number, compound 4's estimate is 1.7-fold (0.22 log units) above it; the range from low to high includes it.
By their numbers in this assay, from the lowest: compound 1; then compound 4; then compound 3.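

In this assay, cyclopentyl shows that a non-aromatic ring of carbon only can stand on this saturated ring carbon, with a 5.3-fold lower number from compound 3 to compound 4 (0.72 log units; beyond the scatter) and with a 7.1-fold higher number from compound 1 to compound 4 (0.85 log units; beyond the scatter) still separating it from 4-methylphenyl. Aromaticity alone does not set the order of the three, since aromatic pyridin-3-yl stands above cyclopentyl and aromatic 4-methylphenyl below it. Nothing measured here accounts for that order.

Open, from the compounds shown here alone, is whether cyclohexyl, or an open chain such as isopropyl, would track cyclopentyl. Also open, going by these compounds, is how a ring carrying an amine, such as piperidin-4-yl, would fare at this place.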